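A Chloro for Fluoro Swap in a Narrow Series

The source may hold more compounds than are shown below. What is called first, only, known or untested is meant among the compounds shown, and "the series" means these compounds.

In a functional assay on PC-3 cells (Homo sapiens) for cytotoxicity, read by MTT assay, with a stated time of 24 h (on this read-out lower numbers stand for stronger inhibition and higher numbers for weaker inhibition), compound 1 (`COc1ccc(/C=C2\CN(C(=S)SCc3cn(Cc4ccccc4F)nn3)C/C(=C\c3ccc(OC)cc3)C2=O)cc1`) gives 31500 nM and compound 3 (`Cc1ccc(/C=C2\CN(Cc3cn(Cc4cccc(Cl)c4)nn3)C/C(=C\c3ccc(C)cc3)C2=O)cc1`) gives a similar number (29300 nM). Compound 2 (`O=C1/C(=C/c2ccccc2F)CN(Cc2cn(Cc3ccccc3F)nn2)C/C1=C\c1ccccc1F`) gives 19700 nM and lies within the scatter of both, so the three cannot be ranked. Compound 4 (`O=C1/C(=C/c2ccccc2F)CN(Cc2cn(Cc3ccccc3Cl)nn2)C/C1=C\c1ccccc1F`) is still unmeasured. It has chloro in place of fluoro on an aromatic carbon, ortho to a large group, turning 2-fluorobenzyl into 2-chlorobenzyl (chloro in place of fluoro on an aromatic carbon). Among the compounds with values here, no measured pair shows this change, so in this assay no step beyond the scatter is expected, in either direction, and the estimate stays close to compound 2 (19700 nM). The expected change is small (a 1.1-fold higher number from compound 2 to compound 4 (0.05 log units; within the scatter)). Compound 4 is estimated at 22000 nM (expected range 11000 nM to 40000 nM).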

Compound 4, half-maximal inhibitory concentration: 7100 nM
For compound 4 the middle estimate is 3.1-fold (0.49 log units) above the measured one; measured number outside the range, below it.
By their numbers in this assay, from the lowest: compound 4; then compounds 2, 3 and 1 (each within the scatter of the next).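

Turning 2-fluorobenzyl into 2-chlorobenzyl gives a 2.8-fold lower number from compound 2 to compound 4 (0.44 log units; beyond the scatter) in this assay, so this position is sensitive to which halogen it carries, something the three earlier compounds, which differ in more than one place, could not show. The step is modest and rests on this single pair. Nothing measured here accounts for it. From the compounds shown here alone, whether a bromo or a nitrile at this position would lower the number further remains open. So does whether chloro in place of fluoro on the 2-fluorophenyl groups would have any effect.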